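The source may report more compounds than this note shows. Statements on the series, on what has been measured and on what is new or still open speak of the compounds shown alone.

Measured compounds:
- compound 1 `COc1ccc(-c2cc(C(=O)Nc3nc4ccc(Cl)cc4s3)nc3cc(-c4ccccc4)nn23)cc1OC`, giving 9120 nM in a functional assay on HeLa cells (Homo sapiens) for cytotoxicity, read by MTT assay, with a stated time of 48 h; on this read-out lower numbers stand for stronger inhibition and higher numbers for weaker inhibition
- compound 2 `O=C(Nc1nc2ccc(F)cc2s1)c1cc(-c2ccc(F)cc2)n2nc(-c3ccccc3)cc2n1`, giving 29500 nM in this assay

Of these two numbers, compound 2 stands highest: compound 1 gives a clearly lower number, and the gap between them lies beyond the usual scatter of this assay. The two compounds differ in two places at once, so the values only show where each stands, not what either change contributes.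

Compound 3 `COc1ccc(-c2cc(C(=O)Nc3nc4ccc(F)cc4s3)nc3cc(-c4ccccc4)nn23)cc1OC` has not yet been measured. It differs from compound 2 in one place: 3,4-dimethoxyphenyl in place of 4-fluorophenyl on an aromatic carbon. The same 3,4-dimethoxyphenyl group is present in compound 1, whose value of 9120 nM is the lower of the two numbers in this assay. The step of a 2.5-fold lower number from compound 2 to compound 3 (0.39 log units; beyond the scatter) is therefore expected to go downward, beyond the scatter but by a modest amount. Compound 3 is estimated at 12000 nM, with a range from 4000 nM to 40000 nM.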

Compound 3, half-maximal inhibitory concentration: 8310 nM
The estimate for compound 3 lay 1.4-fold (0.16 log units) above the measured number, and the stated range covers the measured number.
By their numbers in this assay, from the lowest: compounds 3 and 1 (each within the scatter of the next); then compound 2.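

In this assay, placing 3,4-dimethoxyphenyl in place of 4-fluorophenyl on the aromatic carbon gives a 3.5-fold lower number from compound 2 to compound 3 (0.55 log units; beyond the scatter), a modest step that can be tied to this one position, which the first two compounds, differing in two places, could not show. With 3,4-dimethoxyphenyl held constant, fluoro in place of chloro gives a 1.1-fold lower number from compound 1 to compound 3 (0.04 log units; within the scatter), so this halogen swap makes no visible difference here. Nothing available explains the step at the dimethoxyphenyl position.

Still open, going by these compounds, is whether a single methoxy group on the phenyl ring would give the same step, and how an amine or a carboxylic acid on that ring would read. The halogen comparison is also available only alongside 3,4-dimethoxyphenyl, so it may not hold with 4-fluorophenyl at that position.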